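The source may report more compounds than this note shows. Statements on the series, on what has been measured and on what is new or still open speak of the compounds shown alone.

Compound 2 `CNc1nc(Nc2ccc(C)c(N)c2)ncc1C(=O)Nc1cc(NC(=O)c2cccc(C(F)(F)F)c2)ccc1C` gives 14 nM in a functional assay on K562 cells (Homo sapiens) for antiproliferative activity, read by CellTiter-Glo and CCK-8 assay, with a stated time of 72 h (on this read-out lower numbers stand for stronger inhibition of growth and higher numbers for weaker inhibition of growth), the lowest of the three numbers recorded so far. Compound 1 `CNc1nc(Nc2ccc(C)c([N+](=O)[O-])c2)ncc1C(=O)Nc1cc(NC(=O)c2cccc(C(F)(F)F)c2)ccc1C` gives 52 nM in this assay, and the step of a 3.7-fold lower number from compound 1 to compound 2 (0.57 log units; beyond the scatter). Compound 3 `Cc1ccc(Nc2ncc(C(=O)Nc3cc(NC(=O)c4cccc(C(F)(F)F)c4)ccc3C)cn2)cc1N` gives 330 nM, and the step of a 24-fold higher number from compound 2 to compound 3 (1.37 log units; beyond the scatter). Compound 4 `CNc1nc(Nc2ccc(C)c(N)c2)ncc1C(=O)Nc1cc(NC(=O)c2cc(OC)c(OC)c(OC)c2)ccc1C` differs from compound 2 in another part of the molecule: 3,4,5-trimethoxyphenyl in place of 3-(trifluoromethyl)phenyl on a carbonyl carbon. Going by the values given here, neither of the two measured steps involves this carbonyl; both concern a group on an aromatic carbon elsewhere in the shared core, so no measured step bears directly on the change from compound 2 to compound 4. Among the compounds with values here, the only guidance is that both measured changes moved this assay beyond the scatter, and a swap of an entire aryl group is at least as large a change. A step of modest size is therefore expected, with a weakening of growth inhibition judged somewhat more likely than a strengthening, giving an expected 11-fold higher number from compound 2 to compound 4 (1.03 log units; beyond the scatter). For compound 4 the estimate in this assay is 150 nM, with a range from 30 nM to 800 nM.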

Compound 4, concentration for 50% growth inhibition: 250 nM
The estimate for compound 4 lay 1.7-fold (0.22 log units) below the measured number; low and high end bracket the measured number.
By their numbers in this assay, from the lowest: compound 2; then compound 1; then compounds 4 and 3 (each within the scatter of the next).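

In this assay, the swap of the aryl group on the carbonyl carbon gives an 18-fold higher number from compound 2 to compound 4 (1.25 log units; beyond the scatter), a large step. Going by these compounds alone, both earlier steps concerned groups on aromatic carbons elsewhere in the shared core, so this is the first sign that the group on this carbonyl also strongly affects growth inhibition, with 3-(trifluoromethyl)phenyl giving the lower number in this pair. No accompanying measurement accounts for the size of this step.

With only these two aryl groups compared here, the compounds shown do not separate the loss of trifluoromethyl from the arrival of the three methoxy groups, a question that an unsubstituted phenyl or a phenyl bearing a single methoxy group could address. They also leave open whether a pyridine ring or a morpholine-bearing phenyl would be tolerated on this carbonyl.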